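Bromo, fluoro and nitro benzamides, then a cyano analogue

The compounds below may be only part of what the source reports. "The series", "measured", "known", "first", "only" and "open" are said of these compounds alone.

Measured so far in a functional assay on MCF7 cells (Homo sapiens) for inhibition, read by MTT assay (on this read-out lower numbers stand for stronger inhibition of growth and higher numbers for weaker inhibition of growth), for the compounds below
- compound 1 (`COc1cc2oc(-c3cccc(NC(=O)c4ccc(Br)cc4)c3)cc(=O)c2c(OC)c1OC`) at 9650 nM
- compound 2 (`COc1cc2oc(-c3cccc(NC(=O)c4ccc(F)cc4)c3)cc(=O)c2c(OC)c1OC`) at 14700 nM
- compound 3 (`COc1cc2oc(-c3cccc(NC(=O)c4ccc([N+](=O)[O-])cc4)c3)cc(=O)c2c(OC)c1OC`) at 20100 nM

Compound 3 at 20100 nM stands at the upper end of these numbers, with compound 2 close by (a 1.4-fold higher number from compound 2 to compound 3 (0.14 log units; within the scatter)) and compound 1 modestly apart (a 2.1-fold higher number from compound 1 to compound 3 (0.32 log units; beyond the scatter)). The change to compound 4 (`COc1cc2oc(-c3cccc(NC(=O)c4cccc(C#N)c4)c3)cc(=O)c2c(OC)c1OC`) is 3-cyanophenyl in place of 4-nitrophenyl on a carbonyl carbon. The measured steps that bear on it are the exchanges among bromo, fluoro and nitro, which include the small step (a 1.5-fold higher number from compound 1 to compound 2 (0.18 log units; within the scatter)) alongside the two above. Among the measured compounds shown here, none of the three compounds carries a 3-cyanophenyl group, so the data give no direct step for this change. No step beyond the scatter is therefore expected in this assay, with a slightly lower number the likelier direction. The expected step is a 1.3-fold lower number from compound 3 to compound 4 (0.10 log units; within the scatter) by this estimate. For compound 4 the estimated value is 16000 nM (expected range 8000 nM to 32000 nM).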

Compound 4, concentration for 50% growth inhibition: 41700 nM
Compound 4: middle estimate off by 2.6-fold (0.42 log units), on the low side; the measured number lies above the stated range.
By their numbers in this assay, from the lowest: compounds 1, 2 and 3 (each within the scatter of the next, the first and the last beyond it); then compound 4.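

In this assay the group on the carbonyl carbon now gives a step beyond the scatter from a change of the whole aryl group: 3-cyanophenyl in place of 4-nitrophenyl gives a 2.1-fold higher number from compound 3 to compound 4 (0.32 log units; beyond the scatter) and places compound 4 above all three earlier compounds. Among the compounds shown here, the same group in place of 4-fluorophenyl gives a 2.8-fold higher number from compound 2 to compound 4 (0.45 log units; beyond the scatter) and in place of 4-bromophenyl gives a 4.3-fold higher number from compound 1 to compound 4 (0.64 log units; beyond the scatter) as the largest step so far. No measurement here accounts for this rise.

This change replaces the substituent and its ring position together, and the compounds shown cannot separate the two, since neither 4-cyanophenyl nor 3-nitrophenyl stands among them. Also open, going by these compounds, is how 3-aminophenyl or 4-carboxyphenyl on the same carbonyl carbon would read in this assay.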